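This account rests on a few compounds, and the source may have more. Where it says the series, first, only, none or still open, it means among the compounds named here.

Measured in a functional assay on BV-2 cells (Mus musculus) for inhibition, read by Griess assay, with stated times of 3 h and 24 h; on this read-out higher numbers stand for weaker inhibition and lower numbers for stronger inhibition:
- compound 1 `O=S(=O)(/C=C/c1ccc(O)c(O)c1)NCc1ccccc1` gives 21500 nM
- compound 2 `O=S(=O)(/C=C/c1ccc(O)c(O)c1)NCc1ccc(Cl)cc1` gives 13700 nM
- compound 3 `O=S(=O)(/C=C/c1ccc(O)c(O)c1)NCc1ccc(F)cc1` gives 18900 nM

Compound 3 sits close to both of the others: a 1.1-fold lower number from compound 1 to compound 3 (0.06 log units; within the scatter) and a 1.4-fold higher number from compound 2 to compound 3 (0.14 log units; within the scatter), so none of these three numbers can be told apart with confidence.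

The next compound, compound 4 `COc1ccc(CNS(=O)(=O)/C=C/c2ccc(O)c(O)c2)cc1`, differs from compound 3 by methoxy in place of fluoro on an aromatic carbon. Among the compounds with values here, the steps that bear on this change are those on the same aromatic carbon: a 1.6-fold lower number from compound 1 to compound 2 (0.20 log units; within the scatter), a 1.1-fold lower number from compound 1 to compound 3 (0.06 log units; within the scatter) and a 1.4-fold higher number from compound 2 to compound 3 (0.14 log units; within the scatter). Hydrogen, chloro and fluoro at this position all gave numbers within the scatter of one another, so there is no sign so far that this position moves the read-out of this assay. Methoxy has not been tried, but on this evidence no step beyond the scatter is expected, in either direction.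

Compound 4 is therefore estimated to give 18000 nM, with a range from 8000 nM to 40000 nM. This estimate corresponds to an expected step of a 1.1-fold lower number from compound 3 to compound 4 (0.02 log units; within the scatter).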

Compound 4, half-maximal inhibitory concentration: 26500 nM
Compound 4: middle estimate off by 1.5-fold (0.17 log units), on the low side; low and high end bracket the measured number.
By their numbers in this assay, from the lowest: compounds 2, 3, 1 and 4 (each within the scatter of the next).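

With methoxy in place of fluoro, the position takes on one hydrogen-bond acceptor and a second heavy atom, yet in this assay the result is only a 1.4-fold higher number from compound 3 to compound 4 (0.15 log units; within the scatter) and, against the unsubstituted ring, a 1.2-fold higher number from compound 1 to compound 4 (0.09 log units; within the scatter). Even the widest gap among the four compounds, a 1.9-fold higher number from compound 2 to compound 4 (0.29 log units; within the scatter), stays within the scatter, so hydrogen, chloro, fluoro and methoxy at this position cannot be told apart. No supporting measurement is available to account for these numbers.

On these data alone, whether an amine, a carboxylic acid or a longer chain at this position would give a step beyond the scatter remains open. Also open, as far as these compounds go, is whether changes elsewhere in the core of compound 1, such as at its hydroxyl groups, would move the number in this assay at all.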